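The source may hold more compounds than are shown below. What is called first, only, known or untested is meant among the compounds shown, and "the series" means these compounds.

Compound 2 `O=C(Cn1c(-c2ccc(Cl)cc2)nc2cccnc21)N1CCOCC1` stands highest of the two numbers in hand: in a functional assay on the whole organism with Mus musculus as the target (on this read-out lower numbers stand for an effect already at smaller amounts and higher numbers for an effect only at larger amounts of compound), compound 2 gives 11.5 mg/kg, whereas compound 1 `NC(=O)Cn1c(-c2ccc(Cl)cc2)nc2cccnc21` gives 4.1 mg/kg. Going by the values given here, the only measured step, a 2.8-fold higher number from compound 1 to compound 2 (0.45 log units; beyond the scatter), came with morpholin-4-yl in place of amino on a carbonyl carbon. Compound 3 `CN(C)C(=O)CCn1c(-c2ccc(Cl)cc2)nc2cccnc21` differs from compound 2 by (dimethylcarbamoyl)methyl in place of (morpholin-4-yl)carbonyl on a saturated chain carbon bound to an aromatic nitrogen. Among the compounds with values here, no measured step covers this change; the one step known touches the same end of the molecule but does not repeat here. The expected step is a 1.4-fold lower number from compound 2 to compound 3 (0.16 log units; within the scatter), not beyond the scatter. Compound 3 is estimated at 8 mg/kg, with a range of 3 mg/kg to 20 mg/kg.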

Compound 3, dose for half-maximal effect: 29.4 mg/kg
Estimate against measurement, compound 3: 3.7-fold (0.57 log units) below; measured number outside the range, above it.
By their numbers in this assay, from the lowest: compound 1; then compound 2; then compound 3.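

In this assay, the swap to (dimethylcarbamoyl)methyl on a saturated chain carbon bound to an aromatic nitrogen gives a 2.6-fold higher number from compound 2 to compound 3 (0.41 log units; beyond the scatter) and does not hold the number level. Going by these compounds alone, replacing carbamoyl at the same place gives a 7.2-fold higher number from compound 1 to compound 3 (0.86 log units; beyond the scatter) as the largest step so far, and the two steps point the same way as the earlier morpholine change. No available evidence bears on the reason for these steps.

The change alters chain length and amide together, so their shares cannot be separated. Dimethylcarbamoyl on the shorter chain, or a carboxylic acid at the chain end, remains open.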